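This account rests on a few compounds, and the source may have more. Where it says the series, first, only, none or still open, it means among the compounds named here.

Measured so far:
- compound 1, `O=C(/C=C/c1ccc(Cl)cc1)Nc1cc(-c2ccc(Br)cc2)[nH]n1`, 770 nM in a functional assay on MCF7 cells (Homo sapiens) for antiproliferative activity, read by MTT assay, with a stated time of 48 h; on this read-out lower numbers stand for stronger inhibition and higher numbers for weaker inhibition
- compound 2, `O=C(/C=C/c1ccccc1)Nc1cc(-c2ccc(Br)cc2)[nH]n1`, 1120 nM
- compound 3, `COc1ccc(/C=C/C(=O)Nc2cc(-c3ccc(C)cc3)[nH]n2)cc1`, 860 nM

Among these three numbers compound 3 stands second highest; it lies closest to compound 1 and furthest from compound 2, yet both gaps fall within the usual scatter, so the three compounds cannot be told apart on these values.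

Compound 4, `COc1ccc(/C=C/C(=O)Nc2cc(-c3ccc(Br)cc3)[nH]n2)cc1`, differs from compound 3 by bromo in place of methyl on an aromatic carbon. Among the compounds with values here, the only measured step, a 1.5-fold higher number from compound 1 to compound 2 (0.16 log units; within the scatter), concerns a different place in the molecule, the ring at the far end of the amide-bearing double bond, and it stayed within the scatter. Within the data shown here, no measured step touches the ring carrying the methyl or bromo group, so the change from compound 3 to compound 4 has no direct precedent here. Among the measured compounds shown here, the one step that is known shows a halogen coming or going without a shift beyond the scatter, and a similar outcome is expected for compound 4: a step of about a 1.1-fold lower number from compound 3 to compound 4 (0.03 log units; within the scatter), that is, no change beyond the scatter, in either direction.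

Compound 4 is therefore estimated at 800 nM, with a range from 400 nM to 1600 nM.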

Compound 4, half-maximal inhibitory concentration: 590 nM
The estimate for compound 4 lay 1.4-fold (0.13 log units) above the measured number; measured number inside the range.
By their numbers in this assay, from the lowest: compounds 4, 1, 3 and 2 (each within the scatter of the next).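

In this assay, within the data shown here, the ring carrying the methyl or bromo group can now be read for the first time: going from 4-methylphenyl to 4-bromophenyl gives a 1.5-fold lower number from compound 3 to compound 4 (0.16 log units; within the scatter), so these two groups cannot be told apart at this position. Among these compounds, the new compound also brings the first comparisons of methoxy on the other aromatic ring, where methoxy in place of hydrogen gives a 1.9-fold lower number from compound 2 to compound 4 (0.28 log units; within the scatter) and methoxy in place of chloro gives a 1.3-fold lower number from compound 1 to compound 4 (0.12 log units; within the scatter), so hydrogen, chloro and methoxy on that ring cannot be told apart either. No measurement offered here accounts for how closely these numbers sit together.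

The compounds shown leave open whether any change on either ring can move the number beyond the usual scatter, as every step so far stays within it. An amine or a carboxylic acid in place of the bromo group, or a longer chain such as butoxy in place of methoxy, would put that question to the test, and the amide hydrogen offers a further place to probe.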